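Sec-butyl for methyl on the amino acid carbon

A few compounds are considered here, and "the series" means these few. Any claim that something is new, unique, unknown or untested is made for them only; others in the source may bear on it.

Compound 1 `Cc1nc2ccccc2nc1Oc1ccc(C(=O)N[C@@H](C)C(=O)O)cc1` and compound 2 `CC[C@@H](C)[C@H](NC(=O)c1ccc(Oc2nc3ccccc3nc2C)cc1)C(=O)O` share one core; compound 3 `CCCCCCCCCCCCNc1nc2ccccc2nc1Oc1ccc(C(=O)N[C@@H](C)C(=O)O)cc1` and compound 4 `CCCCCCCCCCCCNc1nc2ccccc2nc1Oc1ccc(C(=O)N[C@H](C(=O)O)[C@H](C)CC)cc1` share another. The difference between the two cores is not broken down here. In a functional assay on HeLa cells (Homo sapiens) for antiproliferative activity, read by MTT assay, with a stated time of 48 h (a higher number here means a weaker inhibitor, a lower number a stronger inhibitor), compound 1 gives 22300 nM, and compound 2 gives 33200 nM. The change from compound 1 to compound 2 is sec-butyl in place of methyl on a saturated chain carbon bound to an amide-type nitrogen and a carbonyl carbon, and the step it made, a 1.5-fold higher number from compound 1 to compound 2 (0.17 log units; within the scatter), is small. Compound 3 gives 6240 nM in this assay, the lowest of the three values, with compound 1 and compound 2 both beyond the scatter from it. Compound 4 carries the same change on the core of compound 3: sec-butyl in place of methyl on a saturated chain carbon bound to an amide-type nitrogen and a carbonyl carbon. Since the change left a 1.5-fold higher number from compound 1 to compound 2 (0.17 log units; within the scatter) on the first core, a step of similarly modest size is expected on the second core, a 1.4-fold higher number from compound 3 to compound 4 (0.16 log units; within the scatter). On that basis compound 4 is expected to give about 9000 nM in this assay, estimated to lie between 4500 nM and 20000 nM. With a single precedent behind it, this expectation is loosely held.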

Compound 4, half-maximal inhibitory concentration: 35500 nM
Estimate against measurement, compound 4: 3.9-fold (0.60 log units) below; the measured number lies above the stated range.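

On the core of compound 3, sec-butyl in place of methyl on a saturated chain carbon bound to an amide-type nitrogen and a carbonyl carbon gives a 5.7-fold higher number from compound 3 to compound 4 (0.76 log units; beyond the scatter) in this assay and so costs clearly more here than on the core of compound 1. The size of the step does not carry from one core to the other in this series: the same change on two cores in this assay, a 1.5-fold higher number (0.17 log units; within the scatter) from compound 1 to compound 2 and a 5.7-fold higher number (0.76 log units; beyond the scatter) from compound 3 to compound 4, 3.8-fold (0.58 log units) apart, beyond the scatter of two such steps

Going by these compounds alone, with one pair on each core, this shows only that the step depends on the core for these four compounds; it does not show which feature of the cores is responsible, or how the change would behave on any further core.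

Still open, going by these compounds, is whether isopropyl or benzyl on the same carbon would follow compound 3 or compound 4 on the core of compound 3. Also open, on these data alone, is whether a shorter alkyl chain on the amine of that core, or a methyl ester in place of the carboxylic acid, would alter the size of the step.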